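A few compounds are considered here, and "the series" means these few. Any claim that something is new, unique, unknown or untested is made for them only; others in the source may bear on it.

Values so far in a functional assay on HeLa cells (Homo sapiens) for inhibition, with a stated time of 72 h; on this read-out higher numbers stand for an effect only at larger amounts of compound and lower numbers for an effect already at smaller amounts
- compound 1 `COc1cc(CNCc2ccccc2)ccc1OCc1ccc(Cl)nc1` gives 90000 nM
- compound 2 `COc1cc(CNCc2ccncc2)ccc1OCc1ccc(Cl)nc1` gives 400 nM

Of these two, compound 2 has the lower number (400 nM). Compound 3 `COc1cc(CNCC2CCCO2)ccc1OCc1ccc(Cl)nc1` carries oxolan-2-yl in place of pyridin-4-yl on a saturated chain carbon bound to an amine nitrogen. Among the measured compounds shown here, the only measured step bearing on this change is large (a 230-fold lower number from compound 1 to compound 2 (2.35 log units; beyond the scatter)) and brought in the pyridin-4-yl that compound 3 gives up. For the measured compounds named here, no compound with oxolan-2-yl has been measured, so the size of the change is uncertain. Part of that large step is expected to be lost, so the change should be smaller than the measured step. A clear move to a higher number in this assay is expected for compound 3, and the estimated change is a 13-fold higher number from compound 2 to compound 3 (1.10 log units; beyond the scatter). For compound 3 the estimate is 5000 nM (expected range 800 nM to 40000 nM).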

Compound 3, half-maximal effective concentration: 66000 nM
The estimate for compound 3 lay 13-fold (1.12 log units) below the measured number; measured number above the stated range.
By their numbers in this assay, from the lowest: compound 2; then compounds 3 and 1 (each within the scatter of the next).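

In this assay, the low number of compound 2 does not carry over to oxolan-2-yl on a saturated chain carbon bound to an amine nitrogen (a 170-fold higher number from compound 2 to compound 3 (2.22 log units; beyond the scatter)). Oxolan-2-yl and phenyl cannot be told apart here (a 1.4-fold lower number from compound 1 to compound 3 (0.13 log units; within the scatter)), so among these three groups only pyridin-4-yl gives a low number. One hydrogen-bond acceptor and one ring hetero atom are not enough on their own, as oxolan-2-yl and pyridin-4-yl share both counts. No measurement at hand explains this difference.

As far as these compounds go, it remains open whether pyridin-3-yl or pyridin-2-yl would keep the low number of compound 2. Also open, from the compounds shown here alone, is whether piperidin-4-yl, a non-aromatic six-membered ring, or a longer chain bearing pyridin-4-yl would do so.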